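The compounds below may be only part of what the source reports. "The series", "measured", "known", "first", "only" and "open" are said of these compounds alone.

Within the data shown here, in a functional assay (aorta) with Rattus norvegicus as the target (a lower number here means that less compound is needed, a higher number that more compound is needed for the effect), compound 1 `COc1ccc(-c2nc(/N=C(\N)[N+]3(C)CCCCC3)sc2-c2ccc(OC)cc2)cc1` gives 21 uM and compound 2 `COc1ccc(-c2nc(C(=O)N3CCCCC3)sc2-c2ccc(OC)cc2)cc1` gives 11 uM as the only numbers so far. These two values lie within the scatter of each other, so compound 2 holds no clear place relative to compound 1.

Compound 3 `CCOC(=O)/C(C#N)=C/c1nc(-c2ccc(OC)cc2)c(-c2ccc(OC)cc2)s1` comes next, and the change from compound 2 is 2-cyano-2-(ethoxycarbonyl)ethenyl in place of (piperidin-1-yl)carbonyl on an aromatic carbon with 2-cyano-2-(ethoxycarbonyl)ethenyl in place of (piperidin-1-yl)carbonyl on an aromatic carbon. Among the measured compounds shown here, one measured step bears on this, namely a 1.9-fold lower number from compound 1 to compound 2 (0.28 log units; within the scatter) with another replacement on an aromatic carbon, and that step stays within the scatter. For the measured compounds named here, no measured compound carries the entering group, and a single step shows no trend. No step beyond the scatter is therefore expected in this assay in either direction, though this expectation rests on thin evidence and needs wide margins.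

Compound 3 is estimated at 12 uM with an expected range from 4 uM to 40 uM for such a measurement. The expected step is a 1.1-fold higher number from compound 2 to compound 3 (0.04 log units; within the scatter) on this estimate.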

Compound 3, concentration for half-maximal effect: > 100 uM
Compound 3: only a limit was reported (the forecaster's own chance of this, stated with the estimate: 10%); at least 8.3-fold (0.92 log units) between middle value and limit.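

In this assay compound 3 stands at a limit of the assay, not at a number: the limit of > 100 uM in this assay, at which 1 of the 3 values shown sits. Even so, the position on the aromatic carbon next to the ring nitrogen and next to the ring sulfur now shows that the group placed there can move the read-out, which the first pair, within the scatter of each other, did not show: 2-cyano-2-(ethoxycarbonyl)ethenyl in place of (piperidin-1-yl)carbonyl gives an at least 9.0-fold higher number from compound 2 to compound 3 (0.95 log units; beyond the scatter). The comparison with the charged piperidinium-bearing group points the same way, with an at least 4.7-fold higher number from compound 1 to compound 3 (0.67 log units; beyond the scatter), so the open-chain group separates from both ring-bearing groups, though these three compounds alone give no cause for that.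

On these data alone, it remains open which part of 2-cyano-2-(ethoxycarbonyl)ethenyl goes with the step, the nitrile, the ethyl ester or the ethenyl link, and how far the true figure for compound 3 lies past its limit. Also open, as far as these compounds go, is whether a free carboxylic acid, a primary amine or a morpholin-4-ylcarbonyl group at this position would fall with compound 2 or with compound 3.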